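Fluoro-methoxy cinnamide analogue of compound 1

The source may report more compounds than this note shows. Statements on the series, on what has been measured and on what is new or still open speak of the compounds shown alone.

Measured compounds:
compound 1 `COc1ccc(C(=O)c2cc(OC)c(OC)c(OC)c2)cc1NC(=O)/C=C/c1cc(OC)c(OC)c(OC)c1` gives 2100 nM
compound 2 `COc1cccc(/C=C/C(=O)Nc2cc(C(=O)c3cc(OC)c(OC)c(OC)c3)ccc2OC)c1` gives 4300 nM
compound 3 `C#CCOc1cccc(/C=C/C(=O)Nc2cc(C(=O)c3cc(OC)c(OC)c(OC)c3)ccc2OC)c1` gives 15300 nM

In a functional assay on ME-180 cells (Homo sapiens) for cytotoxicity, read by MTT assay, with a stated time of 72 h (a higher number here means a weaker inhibitor, a lower number a stronger inhibitor), compound 1 holds the lowest number of the three, with compound 2 nearest and compound 3 furthest off. Compound 4 `COc1cc(/C=C/C(=O)Nc2cc(C(=O)c3cc(OC)c(OC)c(OC)c3)ccc2OC)ccc1F` differs from compound 1 in one place: 4-fluoro-3-methoxyphenyl in place of 3,4,5-trimethoxyphenyl on a double-bonded chain carbon bound to a double-bonded chain carbon. The relevant measured step is a 2.0-fold higher number from compound 1 to compound 2 (0.31 log units; beyond the scatter), where the same trimethoxyphenyl was cut back to a single methoxy group; the added ethynyl of compound 3 gave a 3.6-fold higher number from compound 2 to compound 3 (0.55 log units; beyond the scatter) and is not mirrored here. A small increase beyond the scatter is therefore expected for compound 4, close to the step to compound 2, that is a 1.9-fold higher number from compound 1 to compound 4 (0.28 log units; within the scatter). Compound 4 is estimated at 4000 nM, within 1800 nM to 9000 nM.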

Compound 4, half-maximal inhibitory concentration: 15500 nM
Beside the measured number, compound 4's estimate is 3.9-fold (0.59 log units) below it; the whole stated range lies below it.
By their numbers in this assay, from the lowest: compound 1; then compound 2; then compounds 3 and 4 (each within the scatter of the next).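

In this assay, fluoro in place of hydrogen on an aromatic carbon is no silent change (a 3.6-fold higher number from compound 2 to compound 4 (0.56 log units; beyond the scatter)), and this takes the full replacement of 3,4,5-trimethoxyphenyl well past the trimming to 3-methoxyphenyl alone (a 7.4-fold higher number from compound 1 to compound 4 (0.87 log units; beyond the scatter)). Two different additions to compound 2 end level with each other (a 1.0-fold higher number from compound 3 to compound 4 (0.01 log units; within the scatter)), so 4-fluoro-3-methoxyphenyl and 3-(propargyloxy)phenyl cannot be told apart here. No measurement at hand accounts for the loss.

Open, as far as these compounds go, is whether the loss belongs to fluoro itself or would also follow with chloro or an amine on that aromatic carbon.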